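A few compounds are considered here, and "the series" means these few. Any claim that something is new, unique, unknown or untested is made for them only; others in the source may bear on it.

Working notes on the series. Three compounds have numbers in a functional assay on DLD-1 cells (Homo sapiens) for inhibition, read by MTT assay, with a stated time of 72 h; on this read-out higher numbers stand for weaker inhibition and lower numbers for stronger inhibition. Compound 1 `COc1ccc(CCCNCc2c(OC)cc(Oc3ccc(Nc4ccccc4)cc3)cc2OC)cc1` gives 4650 nM in this assay. Compound 2 `CNCc1c(OC)cc(Oc2cccc(Nc3ccccc3)c2)cc1OC` gives 11900 nM in this assay. Compound 3 `COc1ccc([C@@H](C)NCc2c(OC)cc(Oc3cccc(Nc4ccccc4)c3)c(OC)c2OC)cc1` gives 3500 nM in this assay. Compound 2 stands at the highest of the three numbers: compound 1 is its nearest neighbour and lies below it beyond the scatter, and compound 3 lies further below it, also beyond the scatter. Among the measured compounds shown here, no pair among the three differs in one place only, so no single step between measured compounds is available.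

Compound 4 `COc1cc(Oc2cccc(Nc3ccccc3)c2)cc(OC)c1CNCc1ccccc1` has not yet been measured in this assay. It differs from compound 2 in one place: phenyl in place of hydrogen on a saturated chain carbon bound to an amine nitrogen. Both compound 1 and compound 3 carry a larger group on the amine nitrogen than compound 2 and both give the lower number, though neither is a clean one-place comparison with compound 2. On that basis a modest step toward stronger inhibition in this assay is expected; the estimated step is a 2.2-fold lower number from compound 2 to compound 4 (0.34 log units; beyond the scatter). For compound 4 the expected value in this assay is 5500 nM, with a range from 2200 nM to 13000 nM.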

Compound 4, half-maximal inhibitory concentration: 5220 nM
Estimate against measurement, compound 4: 1.1-fold (0.02 log units) above; the range from low to high includes it.
By their numbers in this assay, from the lowest: compounds 3, 1 and 4 (each within the scatter of the next); then compound 2.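

In this assay, among the compounds shown here, the change from methylamino to benzylamino gives a 2.3-fold lower number from compound 2 to compound 4 (0.36 log units; beyond the scatter), the first reading of this position in which nothing else in the structure changes. Phenyl in place of hydrogen on a saturated chain carbon bound to an amine nitrogen is therefore accepted here, and it moves the number modestly toward stronger inhibition. Nothing available explains this step.

Still open, as far as these compounds go, is whether cyclohexyl, a pyridine ring or a longer chain such as phenylethyl at this carbon would give a larger or smaller step than phenyl. From the compounds shown here alone, this is also a single step on the core of compound 2, so it remains unknown whether the same change would give a similar step on the core of compound 1 or compound 3.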